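Thiobenzyl series: tert-butyl phenyl variant of compound 2

The source may hold more compounds than are shown below. What is called first, only, known or untested is meant among the compounds shown, and "the series" means these compounds.

Two compounds of this series have numbers. Compound 1 `N#Cc1cccc(CSc2ncnc3c2ncn3[C@@H]2O[C@H](CO)[C@@H](O)[C@H]2O)c1` carries a cyano group on the aromatic ring and in an assay on isolated protein for inhibition of Equilibrative nucleoside transporter 1 (Homo sapiens) (a lower number here means a stronger inhibitor, a higher number a weaker inhibitor), compound 1 gives 36.3 nM. Compound 2 `OC[C@H]1O[C@@H](n2cnc3c(SCc4cccc(C(F)(F)F)c4)ncnc32)[C@H](O)[C@@H]1O` carries a trifluoromethyl instead, and in this assay compound 2 gives 19.1 nM. Going by the values given here, the only measured step, a 1.9-fold lower number from compound 1 to compound 2 (0.28 log units; within the scatter), is a trifluoromethyl in place of cyano on an aromatic carbon. Compound 2 thus holds the lower of the two numbers, but its distance from compound 1 lies within the scatter, so neither compound is set apart from the other.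

Compound 3 `CC(C)(C)c1ccc(CSc2ncnc3c2ncn3[C@@H]2O[C@H](CO)[C@@H](O)[C@H]2O)cc1` is the next member. It differs from compound 2 by 4-(tert-butyl)phenyl in place of 3-(trifluoromethyl)phenyl on a saturated chain carbon bound to a sulfur. Among the compounds with values here, no measured step in this assay shows this exchange; the one step that touches the same ring, from compound 1 to compound 2, swapped one substituent for another and stayed within the scatter. On that basis compound 3 is expected to stay close to compound 2, with the step of a 1.3-fold higher number from compound 2 to compound 3 (0.12 log units; within the scatter) not beyond the scatter. The estimate for compound 3 in this assay is 25 nM, with a range from 8 nM to 80 nM.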

Compound 3, inhibition constant: 10000 nM
For compound 3 the middle estimate is 400-fold (2.60 log units) below the measured one, and the stated range ends below it.
By their numbers in this assay, from the lowest: compounds 2 and 1 (each within the scatter of the next); then compound 3.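

In this assay the aryl group on a saturated chain carbon bound to a sulfur proves far from freely exchangeable: 4-(tert-butyl)phenyl gives a 520-fold higher number from compound 2 to compound 3 (2.72 log units; beyond the scatter) and a 280-fold higher number from compound 1 to compound 3 (2.44 log units; beyond the scatter) in the two available comparisons. The earlier compounds shown here showed only a 1.9-fold lower number from compound 1 to compound 2 (0.28 log units; within the scatter) and so gave a flat picture that holds for that pair alone, with compound 3 now set well apart from both. The groups exchanged between compound 2 and compound 3 match in heavy-atom count, aromatic ring, hydrogen-bond donors, hydrogen-bond acceptors and net charge, so these counts do not separate them, and nothing measured here accounts for the step.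

The exchange changes both the substituent and its printed ring position, so the compounds shown do not tell whether the large step follows the tert-butyl group, the 4-position or the two together. Also open, as far as these compounds go, is how 3-(tert-butyl)phenyl or 4-(trifluoromethyl)phenyl would read, and whether an amine or a carboxylic acid on the ring would be tolerated.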